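Swapping a pyridine ring for its bromo relative

The compounds below may be only part of what the source reports. "The series", "measured", "known", "first", "only" and "open" are said of these compounds alone.

Values measured in an ADME assay on A549 cells (Homo sapiens) for cytotoxicity, read by resazurin assay, with a stated time of 48 h (a lower number here means that less compound is tolerated, a higher number that more compound is tolerated), are as follows:
- Compound 1 `CCN(CC)c1ccc(NC(=O)c2cc(Cl)ccc2O)c(Cl)c1` gives 55500 nM
- Compound 2 `O=C(Nc1ccc(NCc2ccc(F)cc2)cc1Cl)c1cc(Cl)ccc1O` gives 54400 nM
- Compound 3 `O=C(Nc1ccc(NCc2ccncc2)cc1Cl)c1cc(Cl)ccc1O` gives 65300 nM

Compound 3 does not stand apart from the other two, with a 1.2-fold higher number from compound 1 to compound 3 (0.07 log units; within the scatter) and a 1.2-fold higher number from compound 2 to compound 3 (0.08 log units; within the scatter) as its steps. Compound 4 `O=C(Nc1ccc(NCc2cccc(Br)n2)cc1Cl)c1cc(Cl)ccc1O` differs from compound 3 in one group: 6-bromopyridin-2-yl in place of pyridin-4-yl on a saturated chain carbon bound to a nitrogen on an aromatic ring. Among the compounds with values here, the closest precedent is the swap at this same place in a 1.2-fold higher number from compound 2 to compound 3 (0.08 log units; within the scatter), and a 1.0-fold lower number from compound 1 to compound 2 (0.01 log units; within the scatter) is equally small. Within the data shown here, none of the measured compounds carries bromine, so that part is untested. No step beyond the scatter is therefore expected in this assay. The expected step is a 1.3-fold lower number from compound 3 to compound 4 (0.12 log units; within the scatter). The estimated value for compound 4 is 50000 nM, within an expected range from 22000 nM to 90000 nM.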

Compound 4, half-maximal cytotoxic concentration: 92300 nM
Beside the measured number, compound 4's estimate is 1.8-fold (0.27 log units) below it, and the stated range ends below it.
By their numbers in this assay, from the lowest: compounds 2, 1, 3 and 4 (each within the scatter of the next).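

In this assay, putting 6-bromopyridin-2-yl in place of pyridin-4-yl gives a 1.4-fold higher number from compound 3 to compound 4 (0.15 log units; within the scatter) and so shows that a bromine-bearing pyridine at this place stays within the scatter. The wider swaps agree, with a 1.7-fold higher number from compound 2 to compound 4 (0.23 log units; within the scatter) and a 1.7-fold higher number from compound 1 to compound 4 (0.22 log units; within the scatter) both also within the scatter, so compounds 1, 2, 3 and 4 read alike in this assay and none goes against that. No supporting evidence is available to explain this result.

On these data alone, whether a carboxylic acid or a longer chain at this place would give a step beyond the scatter remains open.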